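Swapping Methyl for Chloro on the Aryl Ring

A few compounds are considered here, and "the series" means these few. Any claim that something is new, unique, unknown or untested is made for them only; others in the source may bear on it.

The series rests on a shared core in which two compounds have been measured in an assay on isolated protein for inhibition of vitamin D3 receptor (Homo sapiens); a lower number here means a stronger inhibitor, a higher number a weaker inhibitor. Compound 1 `Cc1ccc(-c2csc(=N)n2CC(=O)N2CCN(c3ccccc3)CC2)cc1` gives 1030 nM. Within the data shown here, compound 2 `CC(=O)N1CCN(C(=O)Cn2c(-c3ccc(C)cc3)csc2=N)CC1` gives 2840 nM, and the single measured step, a 2.8-fold higher number from compound 1 to compound 2 (0.44 log units; beyond the scatter), comes from acetyl in place of phenyl on an amine nitrogen in a ring. Compound 2 therefore stands at the highest of the two numbers, with compound 1 nearest at a lower value.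

Compound 3 `CC(=O)N1CCN(C(=O)Cn2c(-c3ccc(Cl)cc3)csc2=N)CC1` differs from compound 2 by chloro in place of methyl on an aromatic carbon, a change on an aromatic carbon of a six-membered aromatic ring of carbon only, that is, 4-methylphenyl to 4-chlorophenyl. Among the measured compounds shown here, no measured step touches this position; the only step known, a 2.8-fold higher number from compound 1 to compound 2 (0.44 log units; beyond the scatter), concerns the amine nitrogen in the ring and says nothing about the aryl substituent. With nothing to point either way, a change of this kind is expected to stay within the scatter. Compound 3 is therefore expected to give about 2500 nM, within a range from 1000 nM to 6500 nM. This estimate is expected to amount to a 1.1-fold lower number from compound 2 to compound 3 (0.06 log units; within the scatter).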

Compound 3, inhibition constant: 2280 nM
Beside the measured number, compound 3's estimate is 1.1-fold (0.04 log units) above it; the range from low to high includes it.
By their numbers in this assay, from the lowest: compound 1; then compounds 3 and 2 (each within the scatter of the next).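

In this assay, the exchange of 4-methylphenyl for 4-chlorophenyl gives a 1.2-fold lower number from compound 2 to compound 3 (0.10 log units; within the scatter), so with acetyl on the ring nitrogen, methyl and chloro on this aromatic carbon cannot be told apart. Among these compounds, this is the first reading at this position: the earlier step, a 2.8-fold higher number from compound 1 to compound 2 (0.44 log units; beyond the scatter), concerned only the group on the amine nitrogen, whereas this one shows that replacing the single carbon of methyl with the single chlorine of chloro leaves the number within the scatter. There is no evidence here that bears on why these two groups read alike.

Among the compounds shown here, whether the same holds with phenyl on the ring nitrogen, the group carried by compound 1, remains open: the aryl exchange is seen only with acetyl in that place. Also open is how this position responds to groups of other kinds, such as an amine, a carboxylic acid, a methoxy group or a longer chain, and to an unsubstituted phenyl, with methyl and chloro being the only substituents shown here.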